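Working notes: from compound 2 to compound 4

The source may report more compounds than this note shows. Statements on the series, on what has been measured and on what is new or still open speak of the compounds shown alone.

Of the compounds shown here, three of the shared core have been measured in a functional assay on HSC-2 cells (Homo sapiens) for cytotoxicity; a higher number here means that more compound is tolerated, a lower number that less compound is tolerated. Compound 1 `O=C1/C(=C/c2ccc(O)cc2)CCC/C1=C\c1ccc([N+](=O)[O-])cc1` gives 8100 nM, compound 2 `O=C1/C(=C/c2ccc(O)cc2)Cc2ccccc2/C1=C\c1ccc([N+](=O)[O-])cc1` gives 5200 nM, and compound 3 `O=C1/C(=C/c2ccc(Cl)cc2)CCC/C1=C\c1ccc([N+](=O)[O-])cc1` gives 1500 nM. The value of compound 2 lies between the other two: compound 1 sits within the scatter of compound 2, while compound 3 lies beyond the scatter on the lower side.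

Compound 4 `COc1ccc(/C=C2\Cc3ccccc3/C(=C\c3ccc([N+](=O)[O-])cc3)C2=O)cc1OC` is not yet measured. It differs from compound 2 in one place: 3,4-dimethoxyphenyl in place of 4-hydroxyphenyl on a double-bonded chain carbon bound to a double-bonded ring carbon. Within the data shown here, the only measured step touching the same aromatic ring is a 5.4-fold lower number from compound 1 to compound 3 (0.73 log units; beyond the scatter), where a single substituent was exchanged rather than the whole ring. Among the measured compounds shown here, no measured step in this set involves a methoxy group. Both changes remove the hydroxy, and on that ground a modest step downward in this assay is expected for compound 4, a 1.7-fold lower number from compound 2 to compound 4 (0.24 log units; within the scatter). Compound 4 is thus estimated at 3000 nM, with a range from 1000 nM to 9000 nM.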

Compound 4, half-maximal cytotoxic concentration: 920 nM
Compound 4: the middle estimate sits 3.3-fold (0.51 log units) above what was measured; the measured number lies below the stated range.
By their numbers in this assay, from the lowest: compounds 4 and 3 (each within the scatter of the next); then compounds 2 and 1 (each within the scatter of the next).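

In this assay, 3,4-dimethoxyphenyl in place of 4-hydroxyphenyl on a double-bonded chain carbon bound to a double-bonded ring carbon gives a 5.7-fold lower number from compound 2 to compound 4 (0.75 log units; beyond the scatter) on the core of compound 2. The earlier step beyond the scatter at this aromatic ring, a 5.4-fold lower number from compound 1 to compound 3 (0.73 log units; beyond the scatter) on the core of compound 1, also removed the hydroxy and also ended at a lower number, so the direction now holds on both cores, with a different entering group each time. No measurement bearing on the origin of this step is available.

The compounds shown do not separate the loss of the hydroxy from the arrival of the two methoxy groups. Going by these compounds, whether a single methoxy, an amine or a carboxylic acid on this aromatic ring would move the number in the same direction also remains open.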